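The source may hold more compounds than are shown below. What is called first, only, known or untested is meant among the compounds shown, and "the series" means these compounds.

For the measured compounds named here, compound 2 `CNC(=O)C1C(C)(C)C1(C)C` is the only member of the series with a number in a functional assay on the whole organism with Rattus norvegicus as the target; on this read-out higher numbers stand for an effect only at larger amounts of compound and lower numbers for an effect already at smaller amounts: compound 2 gives 82 mg/kg. Compound 1 `CC1(C)C(C(N)=O)C1(C)C` reaches only the limit of the assay there, giving > 250 mg/kg. Going by the values given here, the single measured step, an at least 3.0-fold lower number from compound 1 to compound 2 (0.48 log units; beyond the scatter), runs toward lower numbers, and it is also the limit of > 250 mg/kg in this assay, at which 1 of the 2 values shown sits, that bounds its size. Compound 3 `CC1(C)C(C(=O)NCC(N)=O)C1(C)C` differs from compound 2 by carbamoyl in place of hydrogen on a saturated chain carbon bound to an amide-type nitrogen. Among the compounds with values here, no measured step touches that carbon, so the measured step bears only loosely on this change. For compound 3 no shift beyond the scatter is expected, the estimated step being a 1.2-fold higher number from compound 2 to compound 3 (0.09 log units; within the scatter). Compound 3 is therefore expected at 100 mg/kg, between 40 mg/kg and 250 mg/kg.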

Compound 3, dose for half-maximal effect: 82 mg/kg
Compound 3: middle estimate off by 1.2-fold (0.09 log units), on the high side, and the stated range covers the measured number.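

Carbamoyl in place of hydrogen on a saturated chain carbon bound to an amide-type nitrogen gives no change at the digits printed from compound 2 to compound 3 (within the scatter) in this assay and so shows that this carbon tolerates the added group. Carbamoylmethyl in place of hydrogen on an amide-type nitrogen gives an at least 3.0-fold lower number from compound 1 to compound 3 (0.48 log units; beyond the scatter) and matches methyl, so the effect of substitution there is not tied to methyl alone. Both steps from compound 1 are bounds, not sizes, as compound 1 stands at a limit: the limit of > 250 mg/kg in this assay, at which 1 of the 3 values shown sits.

From the compounds shown here alone, whether a longer chain, an amine or a carboxylic acid at this place keeps the number remains open. Any change to the shared core is equally open.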